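Swapping a methylphenyl for a pyridinyl on the amide

The source may hold more compounds than are shown below. What is called first, only, known or untested is meant among the compounds shown, and "the series" means these compounds.

Three amides built on one shared core have been tested in a functional assay on the whole organism (strain Wistar) for inhibition, with Rattus norvegicus as the target, read by paw edema, with a stated time of 24 h, at a dose of 100 mg/kg; a higher number here means more inhibition at the dose given (going by the name of the read-out), a lower number less inhibition. Compound 1 `COc1cc2c(cc1OC)C(CC(=O)Nc1ccccc1)CC2` gives 30%, compound 2 `COc1cc2c(cc1OC)C(CC(=O)Nc1ccc(Cl)cc1)CC2` gives 70%, and compound 3 `COc1cc2c(cc1OC)C(CC(=O)Nc1cccc(C)c1)CC2` gives 41.7%. Compound 3 thus stands second of the three, above compound 1 and well below compound 2. Compound 4 `COc1cc2c(cc1OC)C(CC(=O)Nc1cccnc1)CC2` carries the change (pyridin-3-yl in place of 3-methylphenyl on an amide-type nitrogen). Going by the values given here, two measured steps touch the same ring: a number 11.7 percentage points higher from compound 1 to compound 3 (beyond the scatter) and a number 28.3 percentage points lower from compound 2 to compound 3 (beyond the scatter). Among the compounds with values here, both show that this ring moves the number beyond the scatter, yet no measured compound has a nitrogen in this ring, so the direction is uncertain. Losing the methyl alone would point back toward compound 1, so a modest drop is expected, a number 9.7 percentage points lower from compound 3 to compound 4 (within the scatter). Compound 4 is therefore estimated at 32%, within 15% to 55%.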

Compound 4, a percentage reported as inhibition, in the whole organism at one dose (the size of the read-out at that dose, not a potency): 36.7%
Compound 4: the middle estimate sits 4.7 percentage points below what was measured, and the stated range covers the measured number.
By their numbers in this assay, from the lowest: compounds 1, 4 and 3 (each within the scatter of the next, the first and the last beyond it); then compound 2.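

Placing a ring nitrogen in the aryl group on the amide nitrogen makes no clear difference in this assay, which gives a number 5 percentage points lower from compound 3 to compound 4 (within the scatter) and a number 6.7 percentage points higher from compound 1 to compound 4 (within the scatter). Pyridin-3-yl therefore sits with phenyl and 3-methylphenyl, while the 4-chlorophenyl group stands apart, with a number 33.3 percentage points lower from compound 2 to compound 4 (beyond the scatter). No measurement here explains these numbers.

On these data alone, it remains open whether chlorine itself is needed for the high number of compound 2, or whether a bromine or an amine on this ring would serve as well. As far as these compounds go, the effect of a chloro group on the pyridinyl ring also remains open.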